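The source may report more compounds than this note shows. Statements on the series, on what has been measured and on what is new or still open speak of the compounds shown alone.

Compounds measured so far:
compound 1, `CCn1nc(-c2cccnc2)c2ccccc2c1=O`, 1320 nM;
compound 2, `O=c1c2ccccc2c(-c2cccnc2)nn1CC1CCCCC1`, 209 nM;
compound 3, `O=c1c2ccccc2c(-c2cccnc2)nn1CCSc1nccs1`, 10500 nM.

Among these three, compound 2 gives the lowest number in a functional assay (trachea) with Cavia porcellus as the target; a higher number here means a weaker inhibitor, a lower number a stronger inhibitor: the nearest is compound 1, which sits a 6.3-fold lower number from compound 1 to compound 2 (0.80 log units; beyond the scatter) away when read from the other side, and the furthest is compound 3, reached by a 50-fold higher number from compound 2 to compound 3 (1.70 log units; beyond the scatter). Both steps lie beyond the scatter, so compound 2 is the strongest inhibitor of the three.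

Compound 4, `O=c1c2ccccc2c(-c2cccnc2)nn1CCO`, has not yet been measured in this assay. It differs from compound 2 by hydroxymethyl in place of cyclohexyl on a saturated chain carbon bound to an aromatic nitrogen.

For the measured compounds named here, two measured steps bear on this change. The gain from compound 1 to compound 2, a 6.3-fold lower number from compound 1 to compound 2 (0.80 log units; beyond the scatter), came with a larger group replacing a small one on the same chain carbon; removing the cyclohexyl again would be expected to undo much of that gain. The step of a 50-fold higher number from compound 2 to compound 3 (1.70 log units; beyond the scatter) shows that a different replacement on that carbon weakened inhibition strongly. Hydroxymethyl is small and carries a donor and an acceptor, unlike either comparator, so compound 4 is expected to fall near or somewhat beyond compound 1, that is a step of a 12-fold higher number from compound 2 to compound 4 (1.08 log units; beyond the scatter) toward a higher number. Compound 4 is estimated at 2500 nM, with a range from 600 nM to 10000 nM.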

Compound 4, half-maximal inhibitory concentration: 4570 nM
Beside the measured number, compound 4's estimate is 1.8-fold (0.26 log units) below it, and the stated range covers the measured number.
By their numbers in this assay, from the lowest: compound 2; then compound 1; then compound 4; then compound 3.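

In this assay, compound 4 shows that a hydroxy group on this chain does more than fail to help: with a 3.5-fold higher number from compound 1 to compound 4 (0.54 log units; beyond the scatter) as the step, hydroxy in place of hydrogen on a saturated chain carbon, two bonds along the chain from an aromatic nitrogen, weakens inhibition on its own. Together with an 8.0-fold higher number from compound 1 to compound 3 (0.90 log units; beyond the scatter) as the earlier step, this gives two replacements of hydrogen at that carbon that both weaken inhibition, and a 2.3-fold lower number from compound 3 to compound 4 (0.36 log units; beyond the scatter) as the step between them shows that the size of the loss depends on the group that enters, while compound 2 goes the other way with its cyclohexyl group. Going from cyclohexylmethyl to 2-hydroxyethyl costs more, at a 22-fold higher number from compound 2 to compound 4 (1.34 log units; beyond the scatter) as the step, than the gain of a 6.3-fold lower number from compound 1 to compound 2 (0.80 log units; beyond the scatter) as the step, so this change loses all that the cyclohexyl group gained and more.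

The compounds shown leave open whether a methoxy group, an amine or a carboxylic acid at that carbon would behave like the hydroxy group, and whether a longer chain carrying the hydroxy group would lessen the loss. Nothing given here explains any of these differences.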